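Nitrophenyl positional change in an aminobenzamide series

The source may hold more compounds than are shown below. What is called first, only, known or untested is meant among the compounds shown, and "the series" means these compounds.

Measured compounds, all in a functional assay on U-251 cells (Homo sapiens) for inhibition, read by MTT assay, with a stated time of 2 days (on this read-out higher numbers stand for lower toxicity in this test and lower numbers for higher toxicity in this test), where each value is a limit of the assay and not a number:
compound 1 `Nc1ccccc1NC(=O)c1ccc(NCC(=O)Nc2cccc([N+](=O)[O-])c2)cc1` gives > 100000 nM.
compound 2 `COc1ccc(NC(=O)CNCCCC(=O)Nc2ccccc2N)cc1` gives > 100000 nM.
compound 3 `Nc1ccccc1NC(=O)CCCNCC(=O)Nc1cc(Cl)ccc1Cl` gives > 100000 nM.

Compound 1 stands at the limit of this assay, with no number of its own; this is the limit of > 100000 nM in this assay, at which 3 of the 3 values shown sit. Compound 4 `Nc1ccccc1NC(=O)c1ccc(NCC(=O)Nc2ccc([N+](=O)[O-])cc2)cc1` is not yet measured. It differs from compound 1 in one place: 4-nitrophenyl in place of 3-nitrophenyl on an amide-type nitrogen.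

Among the compounds with values here, no measured step bears directly on this change. Within the data shown here, the only step between measured compounds, a step that the two limits leave unreadable from compound 2 to compound 3, runs from one limit to another and its size cannot be read; it concerns a different part of the molecule in any case. Among the measured compounds shown here, with every compound so far sitting at the same limit, there is nothing on which to base an expectation of a step beyond the scatter in either direction, so the step from compound 1 to compound 4 is expected to be a number no higher from compound 1 to compound 4 (the limit leaves the size open). Compound 4 is therefore expected at 100000 nM, within 40000 nM to 250000 nM, and most probably reported again as a limit rather than a number.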

Compound 4, concentration lethal to 50% of the cells: > 100000 nM
Compound 4 gave a limit, no number (the forecaster's own chance of this, stated with the estimate: 85%); the middle value lies on the limit itself.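

In this assay compound 1 and compound 4 both stand at a limit, not a number, so no step can be read for 4-nitrophenyl in place of 3-nitrophenyl: the limit of > 100000 nM in this assay, at which 4 of the 4 values shown sit.

The compounds shown leave open how the two nitrophenyl compounds would compare in this assay, and whether any compound of this series gives a number there.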